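The source may report more compounds than this note shows. Statements on the series, on what has been measured and on what is new or still open speak of the compounds shown alone.

Of the compounds shown here, three so far carry numbers in a functional assay on BV-2 cells (Mus musculus), read by Griess assay, with stated times of 3 h and 24 h (a lower number here means a stronger inhibitor, a higher number a weaker inhibitor), and they share one core. Compound 1 `COc1ccc(CCC(=O)/C=C/c2ccc(O)c(O)c2)cc1OC` gives 14500 nM in this test, compound 2 `O=C(/C=C/c1ccc(O)c(O)c1)CCCCc1ccccc1` gives 5900 nM and compound 3 `CC(=O)Oc1ccc(/C=C/C(=O)CCc2cccc(Cl)c2)cc1OC(C)=O` gives 8300 nM on the same read-out. Compound 3 falls numerically between the other two, and its gaps to both lie within the scatter.

Compound 4 `COc1ccc(CCC(=O)/C=C/c2ccc(OC(C)=O)c(OC(C)=O)c2)c(OC)c1` is still unmeasured. Among the measured compounds shown here, it carries 2,4-dimethoxyphenyl in place of 3-chlorophenyl on a saturated chain carbon, two bonds along the chain from a carbonyl carbon and no measured step isolates this change.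

The nearest guide is compound 1, which also carries a dimethoxyphenyl group and gives 14500 nM as its value, though it differs from compound 4 elsewhere too. No step beyond the scatter is therefore expected in this assay, with only a slight lean towards a higher number. The estimated step of a 1.2-fold higher number from compound 3 to compound 4 (0.08 log units; within the scatter) stays within the scatter. For compound 4 the estimated value is 10000 nM with an expected range from 4500 nM to 22000 nM as a working figure.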

Compound 4, half-maximal inhibitory concentration: 9300 nM
Compound 4: the middle estimate sits 1.1-fold (0.03 log units) above what was measured; the range from low to high includes it.
By their numbers in this assay, from the lowest: compounds 2, 3, 4 and 1 (each within the scatter of the next, the first and the last beyond it).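

In this assay, among the compounds shown here, the first step confined to this position reads a 1.1-fold higher number from compound 3 to compound 4 (0.05 log units; within the scatter), so 2,4-dimethoxyphenyl and 3-chlorophenyl on a saturated chain carbon, two bonds along the chain from a carbonyl carbon, are not told apart. The position therefore accepts the larger entering aryl group, with its added hydrogen-bond acceptors, without a step beyond the scatter, at least with the shared acetyl esters in place. No measurement at hand accounts for this flat result.

From the compounds shown here alone, whether an amine or a carboxylic acid on the aryl group at this position, or a longer chain leading to it, would move the number beyond the scatter remains open. For the compounds shown here, the effect of the acetyl esters is also open, since no pair of compounds here differs in those esters alone.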